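A Swapped Triazole Orientation on the Seven-Bond Chain

This account rests on a few compounds, and the source may have more. Where it says the series, first, only, none or still open, it means among the compounds named here.

Within the data shown here, in a functional assay on SH-SY5Y cells (Homo sapiens) for cytotoxicity, read by MTT assay, with a stated time of 56 h (a higher number here means that more compound is needed for the effect, a lower number that less compound is needed), compound 3 (`c1ccc(-c2ccccc2-c2cn(CCCCCCCn3cc(-c4cccnc4)nn3)nn2)cc1`) gives 9.1 nM, the lowest of the three numbers measured so far. Compound 1 (`O=C(Nc1ccccc1-c1ccccc1)OCCCCCCCn1cc(-c2cccnc2)nn1`) gives 36 nM and compound 2 (`c1ccc(-c2ccccc2-c2cn(CCCCCCCCn3cc(-c4cccnc4)nn3)nn2)cc1`) gives 74.5 nM, and both lie beyond the scatter from compound 3.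

Compound 4 (`c1ccc(-c2ccccc2-c2cn(CCCCCCCc3cn(-c4cccnc4)nn3)nn2)cc1`) has the same atoms as compound 3, joined differently: 1-(pyridin-3-yl)-1H-1,2,3-triazol-4-yl in place of 4-(pyridin-3-yl)-1H-1,2,3-triazol-1-yl on a saturated chain carbon, seven bonds along the chain from an aromatic nitrogen. On the saturated chain carbon, 1-(pyridin-3-yl)-1H-1,2,3-triazol-4-yl takes the place of 4-(pyridin-3-yl)-1H-1,2,3-triazol-1-yl.

Among the measured compounds shown here, no measured step makes this exchange, so the data give no direct guide to its size or direction. For the measured compounds named here, the only step available is an 8.2-fold lower number from compound 2 to compound 3 (0.91 log units; beyond the scatter), which involves the same group on the chain but alters the chain rather than the group's orientation. It therefore serves only as a rough yardstick for how much a single edit can shift this assay. Because compound 3 sits at 9.1 nM, the lowest number of the three, a modest rise seems more likely than a further fall, and a step smaller than that yardstick is expected. The expected change is a 1.6-fold higher number from compound 3 to compound 4 (0.22 log units; within the scatter). For compound 4 the estimated value is 15 nM, with an expected range of 4 nM to 55 nM.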

Compound 4, half-maximal effective concentration: 84.2 nM
Compound 4: middle estimate off by 5.6-fold (0.75 log units), on the low side; measured number above the stated range.
By their numbers in this assay, from the lowest: compound 3; then compound 1; then compounds 2 and 4 (each within the scatter of the next).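

Within this assay, compound 4 shows that the orientation of the triazole at this saturated chain carbon, seven bonds along the chain from an aromatic nitrogen, matters in its own right: with no atom gained or lost, the exchange gives a step beyond the scatter (a 9.3-fold higher number from compound 3 to compound 4 (0.97 log units; beyond the scatter)), as the earlier change in the chain did (an 8.2-fold lower number from compound 2 to compound 3 (0.91 log units; beyond the scatter)). Compound 3 thus keeps its low number only with this chain and this orientation together, for the reversed orientation gives up that number and leaves compound 4 within the scatter of compound 2 (a 1.1-fold higher number from compound 2 to compound 4 (0.05 log units; within the scatter)). No measurement shown here offers an explanation for the effect of the reversed orientation on the cytotoxicity read-out.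

Still open, as far as these compounds go, is whether 1-(pyridin-3-yl)-1H-1,2,3-triazol-4-yl would behave the same way on a longer chain, or whether the effect of orientation depends on the length of the chain that carries it. Also open, from the compounds shown here alone, is how an amine or a carboxylic acid in place of the pyridin-3-yl group would shift the number for either triazole orientation.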